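Swapping the Nitrophenyl Arm for a Dihydroxyphenyl

The source may report more compounds than this note shows. Statements on the series, on what has been measured and on what is new or still open speak of the compounds shown alone.

Compound 1, `COc1cc(-c2cc(-c3cccc([N+](=O)[O-])c3)nc(-c3ccccc3)n2)cc(OC)c1OC`: in a functional assay on HCT-116 cells (Homo sapiens) for inhibition, read by MTT assay, with a stated time of 48 h (on this read-out lower numbers stand for stronger inhibition and higher numbers for weaker inhibition), compound 1 gives > 25000 nM, a limit of the assay rather than a number.
Compound 2, `COc1cc(-c2cc(-c3ccc(C)cc3)nc(-c3ccccc3)n2)cc(OC)c1OC`: compound 2 gives 15700 nM.
Compound 3, `COc1ccc(-c2cc(-c3cc(OC)c(OC)c(OC)c3)nc(-c3ccccc3)n2)cc1`: compound 3 gives 4780 nM.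

Compound 1 thus stands only at the limit of > 25000 nM in this assay, at which 1 of the 3 values shown sits, with no measured number of its own. Compound 4, `COc1cc(-c2cc(-c3ccc(O)cc3O)nc(-c3ccccc3)n2)cc(OC)c1OC`, differs from compound 1 by 2,4-dihydroxyphenyl in place of 3-nitrophenyl on an aromatic carbon. Two measured steps leave the same 3-nitrophenyl: an at least 1.5-fold lower number from compound 1 to compound 2 (0.20 log units; that floor lies within the scatter) and an at least 5.2-fold lower number from compound 1 to compound 3 (0.71 log units; beyond the scatter). Both move downward, the second clearly so, and a 3.3-fold lower number from compound 2 to compound 3 (0.52 log units; beyond the scatter) shows methoxy ahead of methyl. Hydroxyl groups resemble methoxy more than methyl, so compound 4 is expected to move by an at least 3.5-fold lower number from compound 1 to compound 4 (0.55 log units; beyond the scatter). The estimate for compound 4 is 7000 nM, within 1500 nM to 30000 nM.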

Compound 4, half-maximal inhibitory concentration: 5890 nM
Compound 4: middle estimate off by 1.2-fold (0.07 log units), on the high side; the range from low to high includes it.
By their numbers in this assay, from the lowest: compounds 3 and 4 (each within the scatter of the next); then compound 2. At a limit, above all of these: compound 1.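

Placing 2,4-dihydroxyphenyl at this position gives an at least 4.2-fold lower number from compound 1 to compound 4 (0.62 log units; beyond the scatter), but that size is only a floor: the limit of > 25000 nM in this assay, at which 1 of the 4 values shown sits.

Compared with 4-methoxyphenyl, the same group gives a 1.2-fold higher number from compound 3 to compound 4 (0.09 log units; within the scatter), so the two cannot be told apart in this assay. Compared with 4-methylphenyl, it gives a 2.7-fold lower number from compound 2 to compound 4 (0.43 log units; beyond the scatter), which shows that a ring carrying hydrogen-bond donors can match the best level seen here.

Whether both hydroxyl groups are needed remains open, since a ring with a single hydroxyl is not among the compounds shown. How an amine or a carboxylic acid would fare at this position is also unknown.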